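Nitro in Place of Chloro: Expected Macrophage Tolerance

A few compounds are considered here, and "the series" means these few. Any claim that something is new, unique, unknown or untested is made for them only; others in the source may bear on it.

The measured compounds:
compound 1, `CC(O)Cn1c([N+](=O)[O-])cnc1/C=C/c1ccc(Br)cc1`, 550 nM in an ADME assay on cells (Macrophage, Homo sapiens) for cytotoxicity, read by MTT assay, with a stated time of 24 h; a higher number here means that more compound is tolerated, a lower number that less compound is tolerated
compound 2, `CC(O)Cn1c([N+](=O)[O-])cnc1/C=C/c1cccc(Cl)c1`, 520 nM in this assay
compound 3, `CC(O)Cn1c([N+](=O)[O-])cnc1/C=C/c1ccccc1Cl`, 480 nM in this assay

Compound 2 sits among its two neighbours: the step of a 1.1-fold lower number from compound 1 to compound 2 (0.02 log units; within the scatter) and the step of a 1.1-fold lower number from compound 2 to compound 3 (0.03 log units; within the scatter) are both within the scatter, so the three measured values cannot be told apart. The remaining step, a 1.1-fold lower number from compound 1 to compound 3 (0.06 log units; within the scatter), is likewise within the scatter.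

Compound 4, `CC(O)Cn1c([N+](=O)[O-])cnc1/C=C/c1cccc([N+](=O)[O-])c1`, is not yet measured. Relative to compound 2 it carries nitro in place of chloro on an aromatic carbon. For the measured compounds named here, none of the measured steps exchanges a halogen for a nitro group; all three only move or swap halogens on that ring, and each of them stayed within the scatter. Those steps bear on compound 4 only in the sense that the ring substituent on this double-bonded chain has so far not moved the number in this assay beyond the scatter. Going by these compounds, on that basis no step beyond the scatter is expected from compound 2 to compound 4, though the change itself is untested here. The estimated step is no change at the digits printed from compound 2 to compound 4 (within the scatter). Compound 4 is therefore expected to give about 520 nM in this assay, with a range from 280 nM to 950 nM.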

Compound 4, half-maximal cytotoxic concentration: 430 nM
Compound 4: middle estimate off by 1.2-fold (0.08 log units), on the high side, within the range that was stated.
By their numbers in this assay, from the lowest: compounds 4, 3, 2 and 1 (each within the scatter of the next).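

In this assay, the halogen swaps among compound 1, compound 2 and compound 3 left open whether a group of another kind could stand on this aromatic carbon, and the exchange of chloro for nitro, with three heavy atoms entering for one and two hydrogen-bond acceptors where chloro has none, gives a 1.2-fold lower number from compound 2 to compound 4 (0.08 log units; within the scatter) and so also stays within the scatter. At this place on the ring, meta to a large group, a halogen can therefore give way to this larger group without the number in this assay being told apart from that of compound 2, although this rests on a single exchange. No measurement shown here bears on what lies behind this result.

Going by these compounds, whether an amine or a carboxylic acid on the same aromatic carbon would also stay within the scatter remains open, as does whether nitro would do so elsewhere on the ring. On these data alone, all four compounds also share the same core and side chain, so the effect of a longer chain in place of that side chain is unknown.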